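A few compounds are considered here, and "the series" means these few. Any claim that something is new, unique, unknown or untested is made for them only; others in the source may bear on it.

Measured in a functional assay on PC-9 cells (Homo sapiens) for inhibition, read by MTT assay, with a stated time of 72 h; a higher number here means a weaker inhibitor, a lower number a stronger inhibitor:
- Compound 1 `CCCCCc1c(C)nc2nc(SCc3ccc(Cl)cc3)nn2c1Nc1cc(-c2ccccc2)[nH]n1`: > 50000 nM, a limit of the assay and not a number
- Compound 2 `Cc1cc(Nc2cc(-c3ccccc3)[nH]n2)n2nc(SCC(=O)c3ccccc3)nc2n1`: 4450 nM
- Compound 3 `Cc1cc(Nc2cc(-c3ccccc3)[nH]n2)n2nc(SCc3cccc(Br)c3)nc2n1`: 8900 nM

For the measured compounds named here, compound 3 stands level with compound 2 within the scatter, and these two are the only compounds with true numbers. The next compound, compound 4 `Cc1cc(Nc2cc(-c3ccccc3)[nH]n2)n2nc(SCc3ccc(Cl)cc3)nc2n1`, differs from compound 3 as follows: 4-chlorophenyl in place of 3-bromophenyl on a saturated chain carbon bound to a sulfur. In short, 4-chlorophenyl sits in place of 3-bromophenyl on a saturated chain carbon bound to a sulfur. Going by the values given here, the one measured step at this place, a 2.0-fold higher number from compound 2 to compound 3 (0.30 log units; within the scatter), replaced benzoyl and stayed small. Among the compounds with values here, no measured step covers this exact exchange. No shift beyond the scatter is therefore expected, and the estimated step is a 1.1-fold lower number from compound 3 to compound 4 (0.05 log units; within the scatter). Compound 4 is expected at 8000 nM, with an estimated range of 2500 nM to 25000 nM.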

Compound 4, half-maximal inhibitory concentration: 6710 nM
For compound 4 the middle estimate is 1.2-fold (0.08 log units) above the measured one; the measured number falls inside the stated range.
By their numbers in this assay, from the lowest: compounds 2, 4 and 3 (each within the scatter of the next). At a limit, above all of these: compound 1.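

In this assay the aryl exchange on a saturated chain carbon bound to a sulfur stays within the scatter: the steps read a 1.3-fold lower number from compound 3 to compound 4 (0.12 log units; within the scatter) and a 1.5-fold higher number from compound 2 to compound 4 (0.18 log units; within the scatter) and leave 4-chlorophenyl, 3-bromophenyl and benzoyl untold apart. A second place separates compounds: with hydrogen in place of pentyl on an aromatic carbon, the step is an at least 7.4-fold lower number from compound 1 to compound 4 (0.87 log units; beyond the scatter) and lies beyond the scatter. Compound 1 stands at a limit of the assay, not a number: the limit of > 50000 nM in this assay, at which 1 of the 4 values shown sits.

On these data alone, whether an amine or a carboxylic acid on that chain carbon would leave the scatter stays open. So does how an ethyl chain on the aromatic carbon would read.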